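Clearance of compound 4 after leaving trifluoromethyl

The compounds below may be only part of what the source reports. "The series", "measured", "known", "first", "only" and "open" are said of these compounds alone.

Measured in an in vitro ADME assay on microsomes from liver (Mus musculus) for pharmacokinetics, read by LC-MS, with a stated time of 10 min, tested at 1 uM; on this read-out higher numbers stand for fast clearance and lower numbers for slow clearance:
Compound 1 `COc1ccc(NC(=O)[C@H]2CN(C)C[C@@H]2c2ccc(/C=C/C(=O)Nc3ccccc3N)cc2)cc1`: 54 mL/min/kg
Compound 2 `CC(C)c1ccc(NC(=O)[C@H]2CN(C)C[C@@H]2c2ccc(/C=C/C(=O)Nc3ccccc3N)cc2)cc1`: 54 mL/min/kg
Compound 3 `CN1C[C@H](C(=O)Nc2ccc(C(F)(F)F)cc2)[C@@H](c2ccc(/C=C/C(=O)Nc3ccccc3N)cc2)C1`: 23 mL/min/kg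

In this assay, compound 3 stands lowest of the three at 23 mL/min/kg. Compound 4 `COc1cccc(NC(=O)[C@H]2CN(C)C[C@@H]2c2ccc(/C=C/C(=O)Nc3ccccc3N)cc2)c1` differs from it by 3-methoxyphenyl in place of 4-(trifluoromethyl)phenyl on an amide-type nitrogen. For the measured compounds named here, two measured steps bear on this: a 2.3-fold lower number from compound 1 to compound 3 (0.37 log units; beyond the scatter), where trifluoromethyl replaces methoxy, and a 2.3-fold lower number from compound 2 to compound 3 (0.37 log units; beyond the scatter), where it replaces isopropyl. The other pair shows no change at the digits printed from compound 1 to compound 2 (within the scatter). Going by the values given here, no measured compound carries 3-methoxyphenyl itself, so the evidence is indirect. A rise of similar size is expected, and the estimated change is a 2.2-fold higher number from compound 3 to compound 4 (0.34 log units; beyond the scatter). For compound 4 the expected clearance is 50 mL/min/kg, with an estimated range of 28 mL/min/kg to 85 mL/min/kg.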

Compound 4, clearance: 65 mL/min/kg
The estimate for compound 4 lay 1.3-fold (0.11 log units) below the measured number; measured number inside the range.
By their numbers in this assay, from the lowest: compound 3; then compounds 1, 2 and 4 (each within the scatter of the next).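

In this assay, for the compounds shown here, 3-methoxyphenyl in place of 4-(trifluoromethyl)phenyl on the amide-type nitrogen gives a 2.8-fold higher number from compound 3 to compound 4 (0.45 log units; beyond the scatter), the first direct reading of this exchange with a methoxy-bearing ring in a different form from that of compound 1. Against the other two groups the new ring stays within the scatter, with a 1.2-fold higher number from compound 1 to compound 4 (0.08 log units; within the scatter) and a 1.2-fold higher number from compound 2 to compound 4 (0.08 log units; within the scatter), so only compound 3 stands apart among these four. Nothing available accounts for these differences.

On these data alone, it remains open whether a nitrile or a chlorine atom in place of trifluoromethyl would stand with compound 3 or with the other three.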